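Swapping a benzimidazole for a benzyl group

The source may report more compounds than this note shows. Statements on the series, on what has been measured and on what is new or still open speak of the compounds shown alone.

Compound 1 `Cc1cc(N2CC[C@@H](C)[C@@H](N(C)c3ncnc4[nH]ccc34)C2)n2nc(SCc3nc4ccccc4[nH]3)nc2n1`: > 100000 nM (a limit)
Compound 2 `C[C@@H]1CCN(c2cc(-c3ccccc3)nc3ncnn23)C[C@@H]1N(C)c1ncnc2[nH]ccc12`: > 100000 nM (a limit)

In a functional assay on BGC-823 cells (Homo sapiens) for inhibition, read by MTT assay, with a stated time of 72 h (a lower number here means a stronger inhibitor, a higher number a weaker inhibitor), compound 1 gives only a limit (> 100000 nM) and not a number. Compound 2 also gives only a limit (> 100000 nM). The whole record so far is therefore (the limit of > 100000 nM in this assay, at which 2 of the 2 values shown sit), and no true potency is known for either compound.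

Compound 3 `Cc1cc(N2CC[C@@H](C)[C@@H](N(C)c3ncnc4[nH]ccc34)C2)n2nc(SCCc3ccccc3)nc2n1` keeps the core of compound 1 and changes one group: benzyl in place of 1H-benzimidazol-2-yl on a saturated chain carbon bound to a sulfur. In plain words, this is benzyl in place of 1H-benzimidazol-2-yl on a saturated chain carbon bound to a sulfur. Cut one bond further out, (1H-benzimidazol-2-yl)methyl becomes phenethyl.

Going by the values given here, no pair of measured compounds differs in just one place, so no measured step shows how much such a swap matters. In this assay no step beyond the scatter is expected, in either direction. This expectation rests on compound 1 and its limit (> 100000 nM) . The estimated change is a number no higher from compound 1 to compound 3 (the limit leaves the size open), and a reading at the limit again is quite likely. For compound 3 the estimated value is 100000 nM, with an expected range from 30000 nM to 300000 nM.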

Compound 3, half-maximal inhibitory concentration: 28000 nM
Compound 3: the middle estimate sits 3.6-fold (0.55 log units) above what was measured; measured number outside the range, below it.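

In this assay, the group carried on the sulfur turns out to matter, with an at least 3.5-fold lower number from compound 1 to compound 3 (0.55 log units; beyond the scatter). The earlier compounds shown here showed only limits, whereas compound 3 gives a true number, so this position can shift the read-out when (1H-benzimidazol-2-yl)methyl gives way to phenethyl. The real size of the step remains unknown because compound 1 has only a limit, and such limits are common in this small set: the limit of > 100000 nM in this assay, at which 2 of the 3 values shown sit.

This one change removes the fused five-membered ring with its two nitrogens and also the hydrogen-bond donor and acceptor counted in that group, so the step alone cannot say which of these differences counts, or whether the larger ring system, the nitrogens or the chain length is what matters. Also open, from the compounds shown here alone, is how the read-out would respond to other groups at the end of the chain on the sulfur, such as a pyridine ring, an amine or a carboxylic acid, or to a longer chain such as 3-phenylpropyl.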